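This account rests on a few compounds, and the source may have more. Where it says the series, first, only, none or still open, it means among the compounds named here.

Of the compounds shown here, three built on the same core have already been tested in a functional assay on the whole organism (strain Kunming) with Mus musculus as the target, with a stated time of 0.5 h, at a dose of 300 mg/kg by the intraperitoneal route; a higher number here means a weaker effect of the compound at the dose given, a lower number a stronger effect. Compound 1 `COc1cc(OC)c(OC)cc1/C=C/COC(=O)/C=C/c1c(OC)ccc(OC)c1OC` gives 100% in this assay. Compound 3 `COc1cc(OC)c(OC)cc1/C=C/COC(=O)/C=C/c1cc(OC)c(OC)c(OC)c1` gives 100% in this assay. Compound 2 `COc1cc(OC)c(OC)cc1/C=C/COC(=O)/C=C/c1ccc(Br)cc1` gives 100% in this assay, level with compound 1 and with compound 3 at the digits shown, and none of the three values is separated from another by more than the usual scatter, so no order among them can be read from these numbers.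

Compound 4 `COc1cc(OC)c(OC)cc1/C=C/COC(=O)/C=C/c1ccccc1Cl` has not yet been measured. It differs from compound 2 in one place: 2-chlorophenyl in place of 4-bromophenyl on a double-bonded chain carbon bound to a double-bonded chain carbon.

Going by the values given here, no pair of measured compounds that differ in only one place is available to show how large a single change of this kind moves the read-out. What the three values at hand do show is that three quite different groups on that double-bonded chain carbon all land on the same number. The expectation for compound 4 is therefore no step beyond the scatter, with the estimated step of no change at the digits printed from compound 2 to compound 4 (within the scatter). In this assay compound 4 is expected to give 100%, with a range from 85% to 100%.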

Compound 4, a percentage reported as activity, at one dose (the size of the read-out at that dose, not a potency): 100%
Estimate against measurement, compound 4: no gap at the digits printed, within the range that was stated.
By their numbers in this assay, from the lowest: compounds 1, 2, 3 and 4 (each within the scatter of the next).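

Going by these compounds alone, putting 2-chlorophenyl in place of 4-bromophenyl on a double-bonded chain carbon bound to a double-bonded chain carbon gives no change at the digits printed from compound 2 to compound 4 (within the scatter) in this assay and is the first comparison here between two compounds that differ in one place. The earlier compounds shown here could only suggest that this position tolerates different groups, whereas this pair shows directly that one exchange of groups leaves the read-out level. That exchange alters both the halogen and the number in the group's name, so this single pair cannot separate the two alterations, and no measurement offered here explains why the read-out stays level.

Going by these compounds, every group seen so far at this position is a substituted phenyl ring, so it remains open whether a phenyl ring carrying an amine or a carboxylic acid, or a longer chain in place of the ring, would move the number. All of these readings also come from a single dose, which leaves open whether compounds that read level at that dose would still do so at a lower one.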